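A few compounds are considered here, and "the series" means these few. Any claim that something is new, unique, unknown or untested is made for them only; others in the source may bear on it.

Working notes on the series. In a functional assay on CWR22R cells (Homo sapiens) for antiproliferative activity, read by propidium iodide staining, with a stated time of 96 h (on this read-out lower numbers stand for stronger inhibition and higher numbers for weaker inhibition), compound 1 `CC(O)(CSc1ccc(S(F)(F)(F)(F)F)cc1)C(=O)Nc1cccc(S(F)(F)(F)(F)F)c1` gives 13100 nM, compound 2 `CC(O)(CSc1ccc(F)cc1)C(=O)Nc1cccc(S(F)(F)(F)(F)F)c1` gives 30200 nM and compound 3 `CC(O)(CSc1ccc(C(F)(F)F)cc1)C(=O)Nc1cccc(S(F)(F)(F)(F)F)c1` gives 26900 nM. Compound 3 stands level with compound 2 within the scatter and apart from compound 1, whose steps to both others lie beyond it.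

The next change leads to compound 4 `CC(O)(CSc1ccc(OC(F)(F)F)cc1)C(=O)Nc1cccc(S(F)(F)(F)(F)F)c1`: trifluoromethoxy in place of trifluoromethyl on an aromatic carbon, para to a large group (trifluoromethoxy in place of trifluoromethyl on an aromatic carbon).

All three measured steps fall at this same place. Fluoro replaced by trifluoromethyl gives a 1.1-fold lower number from compound 2 to compound 3 (0.05 log units; within the scatter). Replacing the group of compound 1 gives a 2.3-fold higher number from compound 1 to compound 2 (0.36 log units; beyond the scatter) and a 2.1-fold higher number from compound 1 to compound 3 (0.31 log units; beyond the scatter), both modest. Within the data shown here, compound 1 is thus the only compound that stands apart from an otherwise flat set, and no data yet cover a trifluoromethoxy group.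

Given a 1.1-fold lower number from compound 2 to compound 3 (0.05 log units; within the scatter) for the closest comparison, no change beyond the scatter is expected in this assay. The expected step is a 1.1-fold lower number from compound 3 to compound 4 (0.05 log units; within the scatter), with no firm direction. For compound 4 the estimated value is 24000 nM, with an expected range of 12000 nM to 45000 nM.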

Compound 4, half-maximal inhibitory concentration: 17000 nM
Compound 4: the middle estimate sits 1.4-fold (0.15 log units) above what was measured, within the range that was stated.
By their numbers in this assay, from the lowest: compounds 1, 4, 3 and 2 (each within the scatter of the next, the first and the last beyond it).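

In this assay, trifluoromethoxy is the only replacement shown for the sulfur-and-fluorine group of compound 1, on this aromatic carbon para to a large group, that stays within the scatter of it, with a 1.3-fold higher number from compound 1 to compound 4 (0.11 log units; within the scatter) as the step. Among these compounds, the same compound also stays within the scatter of the two others, with a 1.6-fold lower number from compound 3 to compound 4 (0.20 log units; within the scatter) and a 1.8-fold lower number from compound 2 to compound 4 (0.25 log units; within the scatter) as its steps, so compound 1 no longer stands wholly apart: the four compounds now form a chain of close neighbours, and only the steps from compound 1 to compound 2 and to compound 3 lie beyond the scatter. No measurement at hand bears on why the numbers fall this way.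

Every group shown at this place carries fluorine, and all four compounds share the rest of the core, so these numbers give no reading of how an amine, a carboxylic acid or a longer chain would behave there. From the compounds shown here alone, whether any change at this place can move the number by more than a modest step, or whether changes elsewhere on the core matter more, also remains open.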